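Pyridinyl for Bromophenyl on a Triazole: Three Compounds at the Limit

A few compounds are considered here, and "the series" means these few. Any claim that something is new, unique, unknown or untested is made for them only; others in the source may bear on it.

Compound 1 `C=C1C[C@]23C[C@@]1(O)CC[C@H]2c1ccc(O)c(C)c1[C@@H]3Cn1cc(-c2ccccn2)nn1`: > 20000 nM
Compound 2 `C=C1C[C@]23C[C@@]1(O)CC[C@H]2c1ccc(O)c(C)c1[C@@H]3Cn1cc(-c2ccc(Br)cc2)nn1`: > 20000 nM
Compound 3 `C=C1C[C@]23C[C@@]1(O)CC[C@@H]2c1cccc(C)c1[C@@H]3Cn1cc(-c2ccc(Br)cc2)nn1`: > 20000 nM

All three were tested in a functional assay on A549 cells (Homo sapiens) for cytotoxicity, read by MTT assay, with a stated time of 4 days; on this read-out higher numbers stand for weaker inhibition and lower numbers for stronger inhibition. Compound 1 gives only the limit of the assay, > 20000 nM, and no number. Compound 2 likewise gives only the limit, > 20000 nM. Compound 3 also stops at the limit, > 20000 nM. The change from compound 2 to compound 1 is pyridin-2-yl in place of 4-bromophenyl on an aromatic carbon; its step is a step that the two limits leave unreadable from compound 2 to compound 1, since both ends sit at the limit of > 20000 nM in this assay, at which 3 of the 3 values shown sit. The difference between the cores of compound 2 and compound 3 is not broken down here.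

Compound 4 `C=C1C[C@]23C[C@@]1(O)CC[C@@H]2c1cccc(C)c1[C@@H]3Cn1cc(-c2ccccn2)nn1` has not been measured. It differs from compound 3 by pyridin-2-yl in place of 4-bromophenyl on an aromatic carbon, the same change as that from compound 2 to compound 1. Because that earlier pair both rest at the limit of > 20000 nM in this assay, at which 3 of the 3 values shown sit, compound 4 is expected to remain at the limit as well, with an expected step that the limit leaves unreadable from compound 3 to compound 4. The estimate for compound 4 in this assay is 30000 nM, between 15000 nM and 100000 nM.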

Compound 4, half-maximal inhibitory concentration: > 20000 nM
Compound 4 was reported as a limit; the forecaster's own chance of this, stated with the estimate: 85%; the middle value does not contradict the limit.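

In this assay compound 4 gives > 20000 nM, which is a limit and not a number. No step can be read between compound 3 and compound 4, because both stop at the same limit: the limit of > 20000 nM in this assay, at which 4 of the 4 values shown sit.

The compounds shown leave open how pyridin-2-yl and 4-bromophenyl compare in this read-out, on either core.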